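From phenyl to 1-benzofuran-2-yl at the assay limit

The source may report more compounds than this note shows. Statements on the series, on what has been measured and on what is new or still open speak of the compounds shown alone.

Measured in a functional assay on HL-60 cells (Homo sapiens) for antiproliferative activity, read by XTT assay, with a stated time of 72 h; a higher number here means a weaker inhibitor, a lower number a stronger inhibitor:
Compound 1 `Cc1nc(N)c2c(-c3ccco3)cn([C@@H]3O[C@H](CO)[C@@H](O)[C@H]3O)c2n1`: > 20000 nM, a limit
Compound 2 `Cc1nc(N)c2c(-c3ccccc3)cn([C@@H]3O[C@H](CO)[C@@H](O)[C@H]3O)c2n1`: > 20000 nM, a limit

Compound 2 stands at the limit of > 20000 nM in this assay, at which 2 of the 2 values shown sit, which is a limit and not a number. Compound 3 `Cc1nc(N)c2c(-c3cc4ccccc4o3)cn([C@@H]3O[C@H](CO)[C@@H](O)[C@H]3O)c2n1` differs from it at one place, (1-benzofuran-2-yl in place of phenyl on an aromatic carbon), with 1-benzofuran-2-yl in place of phenyl on an aromatic carbon. For the measured compounds named here, the only measured step bearing on this change is a step that the two limits leave unreadable from compound 1 to compound 2, so there is no size to carry forward. The step expected in this assay is a number no higher from compound 2 to compound 3 (the limit leaves the size open), with no clear direction. Compound 3 is expected near 20000 nM, within an estimated range of 6000 nM to 40000 nM.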

Compound 3, half-maximal inhibitory concentration: > 20000 nM
Compound 3: only a limit was reported; the forecaster's own chance of this, stated with the estimate: 80%; the middle value sits exactly at the limit.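

Compound 3 also gives only a limit, so no step among compound 1, compound 2 and compound 3 can be read: the limit of > 20000 nM in this assay, at which 3 of the 3 values shown sit.

As far as these compounds go, whether furan-2-yl, phenyl and 1-benzofuran-2-yl differ at all in their effect on the shared core stays open.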